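A Second Fluorine on the Sulfonyl Aryl Ring

A few compounds are considered here, and "the series" means these few. Any claim that something is new, unique, unknown or untested is made for them only; others in the source may bear on it.

Measured so far:
- compound 1, `COc1ccc2ncc(S(=O)(=O)c3ccc(C)c(F)c3)c(N3CCC(C)CC3)c2c1`: 73%
- compound 2, `COc1ccc2ncc(S(=O)(=O)c3ccc(OC)c(OC)c3)c(N3CCC(C)CC3)c2c1`: -3%
- compound 3, `COc1ccc2ncc(S(=O)(=O)c3cccc(F)c3)c(N3CCC(C)CC3)c2c1`: 68%

In an assay on isolated protein for displacement of a labelled ligand from metabotropic glutamate receptor 5 (Homo sapiens), with a stated time of 60 min, tested at 1 uM (a lower number here means less inhibition, a higher number more inhibition at the concentration tested (going by the name of the read-out)), compound 3 stands second highest of the three; compound 1 is the nearest at a number 5 percentage points lower from compound 1 to compound 3 (within the scatter), and compound 2 is the furthest at a number 71 percentage points higher from compound 2 to compound 3 (beyond the scatter). Compound 4, `COc1ccc2ncc(S(=O)(=O)c3cc(F)cc(F)c3)c(N3CCC(C)CC3)c2c1`, has not yet been tested. It differs from compound 3 in one place: fluoro in place of hydrogen on an aromatic carbon, so the ring on the sulfonyl sulfur goes from 3-fluorophenyl to 3,5-difluorophenyl.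

Two kinds of step bear on this. The small change a number 5 percentage points lower from compound 1 to compound 3 (within the scatter) shows that swapping a single small group on that ring leaves the read-out where it was. The large drops a number 76 percentage points lower from compound 1 to compound 2 (beyond the scatter) and, in reverse, a number 71 percentage points higher from compound 2 to compound 3 (beyond the scatter) concern the 3,4-dimethoxyphenyl ring, a different and bulkier pattern, and so say little about a second fluoro. On that basis only a small step is expected in this assay, likely within the scatter: a number 2 percentage points higher from compound 3 to compound 4 (within the scatter). Compound 4 is estimated at 70%, with a range from 50% to 85%.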

Compound 4, a percentage reported as inhibition, at one concentration (the size of the read-out at that concentration, not a potency): 30%
The estimate for compound 4 lay 40 percentage points above the measured number; the whole stated range lies above it.
By their numbers in this assay, from the lowest: compound 2; then compound 4; then compounds 3 and 1 (each within the scatter of the next).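

Adding a single fluoro to the 3-fluorophenyl ring, only one heavy atom, gives a number 38 percentage points lower from compound 3 to compound 4 (beyond the scatter) in this assay, so this ring does not accept every small change. The size of a change is therefore a poor guide here, as removing the methyl group from a different ring carbon gave only a number 5 percentage points lower from compound 1 to compound 3 (within the scatter). The number with the 3,5-difluorophenyl ring is also lower than with the 3-fluoro-4-methylphenyl ring, with a number 43 percentage points lower from compound 1 to compound 4 (beyond the scatter), yet it is higher than with the 3,4-dimethoxyphenyl ring, with a number 33 percentage points higher from compound 2 to compound 4 (beyond the scatter), so the sulfonyl aryl ring now gives an intermediate level of inhibition as well as the high and low levels seen before.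

No measurement available here explains why the added fluoro has this effect. These compounds leave open whether the loss follows from a fluoro at that ring carbon by itself or from the two fluoro groups together, and whether a chlorine atom or a nitrile at the same carbon would give a similar step.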